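Allyl for phenyl on the ring nitrogen: compound 4

The source may report more compounds than this note shows. Statements on the series, on what has been measured and on what is new or still open speak of the compounds shown alone.

Measured so far in a functional assay on aorta with Alpha-1D adrenergic receptor (Rattus norvegicus) as the target; on this read-out higher numbers stand for an effect only at larger amounts of compound and lower numbers for an effect already at smaller amounts:
compound 1, `CSc1ccc(Cc2nn(C(C)(C)C)c(=O)c3ccccc23)cc1`: > 100000 nM
compound 2, `COc1ccc(Cc2nn(-c3ccccc3)c(=O)c3ccccc23)cc1OC`: > 100000 nM
compound 3, `Oc1nnc(Cc2ccc3ccccc3c2)c2ccccc12`: > 10000 nM

None of these three values is a number; each is a limit of the assay. Compound 1 sits at the limit of > 100000 nM in this assay, at which 2 of the 3 values shown sit. Compound 2 sits at the limit of > 100000 nM in this assay, at which 2 of the 3 values shown sit, as well, so compound 2 stands at the upper end of what this assay reports, with no number that would place it against the others. Compound 3 sits at the limit of > 10000 nM in this assay, at which 1 of the 3 values shown sits. For the measured compounds named here, no pair among the three differs in only one place, so no measured step is available.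

Compound 4, `C=CCn1nc(Cc2ccc(OC)c(OC)c2)c2ccccc2c1=O`, differs from compound 2 by allyl in place of phenyl on an aromatic nitrogen. With every measured compound of the series at a limit, the data give no ground for a move beyond the scatter in either direction for this change. Compound 4 is therefore expected to come out at 100000 nM, most likely again as a limit rather than a number. The estimated range for compound 4 runs from 20000 nM to 500000 nM. The step this estimate means is expected to be a number no higher from compound 2 to compound 4 (the limit leaves the size open).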

Compound 4, half-maximal effective concentration: 9800 nM
Estimate against measurement, compound 4: 10-fold (1.01 log units) above, and the stated range ends above it.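

In this assay, allyl in place of phenyl on an aromatic nitrogen gives an at least 10-fold lower number from compound 2 to compound 4 (1.00 log units; beyond the scatter), which makes this nitrogen the first place in the series where a single change is seen to shift the read-out. Compound 4 gives 9800 nM, the only value among the compounds shown that is a number and not a limit. The value of compound 2 is a limit of the assay: the limit of > 100000 nM in this assay, at which 2 of the 4 values shown sit.

From the compounds shown here alone, the full size of the step therefore stays unknown, and the pair does not separate the loss of the phenyl ring from the entry of the double bond. Going by these compounds, whether the shift depends on the double bond or holds for other groups on this nitrogen remains open, and a saturated propyl chain, a longer butyl chain or a chain ending in an amine would address this.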